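Swapping phenyl for an aminooxane on a shared core

The compounds below may be only part of what the source reports. "The series", "measured", "known", "first", "only" and "open" are said of these compounds alone.

Compound 3 `Cc1cc(-c2ccccc2)n(-c2nc(C(F)(F)F)cc(=O)[nH]2)n1` was tested in an ADME assay on CHO cells (Cricetulus griseus) for cytotoxicity, read by MTT assay; on this read-out lower numbers stand for stronger inhibition and higher numbers for weaker inhibition. In this assay compound 3 gives > 50000 nM, which is a limit of the assay rather than a number. Compound 2 `Cc1cc(C)n(-c2nc(-c3ccc(NS(C)(=O)=O)cc3)cc(=O)[nH]2)n1` also reaches only a limit, at > 50000 nM. Compound 1 `Cc1cc(C)n(-c2nc(O)cc(-c3ccccc3)n2)n1` gives 8000 nM. Thus compound 3 sits at the limit of > 50000 nM in this assay, at which 2 of the 3 values shown sit, where compound 2 stands too, while compound 1 alone shows a number. Compound 4 `Cc1cc(NC2CCOCC2)n(-c2nc(C(F)(F)F)cc(=O)[nH]2)n1` differs from compound 3 in one place: (oxan-4-yl)amino in place of phenyl on an aromatic carbon. Going by the values given here, no pair of measured compounds shows this change, so no step beyond the scatter is expected, and the expected step is a number no higher from compound 3 to compound 4 (the limit leaves the size open). Compound 4 is expected to give 50000 nM, most likely between 20000 nM and 150000 nM.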

Compound 4, half-maximal inhibitory concentration: 18000 nM
Compound 4: the middle estimate sits 2.8-fold (0.44 log units) above what was measured, and the stated range ends above it.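

At the aromatic carbon next to the ring nitrogen, (oxan-4-yl)amino in place of phenyl gives an at least 2.7-fold lower number from compound 3 to compound 4 (0.44 log units; beyond the scatter) in this assay, so a change at this position can move the read-out beyond the scatter. Compound 3 stands at > 50000 nM, which is a limit and not a number. The true size of the step stays unknown because it starts from that limit: the limit of > 50000 nM in this assay, at which 2 of the 4 values shown sit.

On these data alone, what remains open is which part of the new group matters. A plain amino group or a cyclohexylamino group at this position could separate the amino link from the ring oxygen.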